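The source may report more compounds than this note shows. Statements on the series, on what has been measured and on what is new or still open speak of the compounds shown alone.

Series notes. Compound 2 `COc1ccc(CN(C(=O)C[Se]C#N)c2cc(OC)c(OC)c(OC)c2)cc1O` holds the lowest number of the three measured compounds: in a functional assay on KYSE-450 cells (Homo sapiens) for inhibition, read by MTT assay, with a stated time of 48 h (on this read-out higher numbers stand for weaker inhibition and lower numbers for stronger inhibition), compound 2 gives 280 nM. Compound 1 `COc1ccc(N(Cc2cc(OC)c(OC)c(OC)c2)C(=O)CCl)cc1O` gives 29800 nM and compound 3 `COc1ccc(CNc2cc(OC)c(OC)c(OC)c2)cc1Cl` gives 47800 nM, both beyond the scatter from compound 2. Going by the values given here, no pair of measured compounds differs in one place only, so no single-change step is known here. Compound 4 `COc1ccc(CN(C(=O)C(C)C)c2cc(OC)c(OC)c(OC)c2)cc1O` differs from compound 2 as follows: a group of 3 heavy atoms (3 carbon; no ring) in place of a group of 4 heavy atoms (2 carbon, 1 nitrogen, 1 selenium; no ring), on a carbonyl carbon. Among the compounds with values here, with no comparable step to lean on, a sizeable loss of inhibition is expected because the lowest number in the set belongs to compound 2 at 280 nM and no other compound comes near it. The step from compound 2 to compound 4 is expected to be a 54-fold higher number from compound 2 to compound 4 (1.73 log units; beyond the scatter). Compound 4 is estimated at 15000 nM, in the range 3000 nM to 60000 nM.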

Compound 4, half-maximal inhibitory concentration: 390 nM
Beside the measured number, compound 4's estimate is 38-fold (1.59 log units) above it; measured number outside the range, below it.
By their numbers in this assay, from the lowest: compounds 2 and 4 (each within the scatter of the next); then compounds 1 and 3 (each within the scatter of the next).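

In this assay, isopropyl in place of the selenium-containing group on the carbonyl carbon gives a 1.4-fold higher number from compound 2 to compound 4 (0.14 log units; within the scatter) and so leaves the number unchanged within the scatter. For this pair, neither the selenium nor the triple bond is needed at this position to hold a number in this range, and a plain all-carbon group serves as well. No measured evidence on this change is at hand.

From the compounds shown here alone, whether a longer chain such as n-butyl, or an amine such as dimethylamino, holds the number at this position stays open. So does whether a carboxylic acid there would do the same.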